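This account rests on a few compounds, and the source may have more. Where it says the series, first, only, none or still open, it means among the compounds named here.

Working notes on the series.

Compound 3 `CN(C1CCN(CCCc2c[nH]c3ccc(-n4cnnc4)cc23)CC1)S(=O)(=O)c1ccccc1` sits second highest of the three numbers in hand: in an assay on CHO cells for displacement of a labelled ligand from 5-hydroxytryptamine receptor 1D (Homo sapiens) (a lower number here means a stronger inhibitor, a higher number a weaker inhibitor), compound 3 gives 1.5 nM. Its nearest neighbour is compound 2 `C[C@@H](NCC1CCN(CCCc2c[nH]c3ccc(-n4cnnc4)cc23)CC1)c1ccccc1`, which in this assay gives 1.4 nM; the pair differ by a 1.1-fold higher number from compound 2 to compound 3 (0.03 log units; within the scatter). Furthest away is compound 1 `O=S(=O)(NCC1CCN(CCCc2c[nH]c3ccc(-n4cnnc4)cc23)CC1)c1ccccc1`, which in this assay gives 6.2 nM; the step of a 4.1-fold lower number from compound 1 to compound 3 (0.62 log units; beyond the scatter) lies beyond the scatter.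

Compound 4 `c1ccc(CNC2CCN(CCCc3c[nH]c4ccc(-n5cnnc5)cc34)CC2)cc1` is not yet measured. The change is benzylamino in place of methyl(phenylsulfonyl)amino on a saturated ring carbon. Within the data shown here, two measured steps bear on it. Replacing phenylsulfonyl with a benzylic carbon on the amine nitrogen gave a 4.4-fold lower number from compound 1 to compound 2 (0.65 log units; beyond the scatter). Moving from a benzylic amine on a methylene to a methylated sulfonamide directly on the ring gave a 1.1-fold higher number from compound 2 to compound 3 (0.03 log units; within the scatter), within the scatter. Compound 4 combines a benzylic amine with direct attachment to the ring, so no step beyond the scatter in this assay is expected, with a slight lean toward a lower number. Compound 4 is estimated at 1.2 nM in this assay, range 0.5 nM to 4 nM, meaning an expected 1.3-fold lower number from compound 3 to compound 4 (0.10 log units; within the scatter).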

Compound 4, half-maximal inhibitory concentration: 4.6 nM
Compound 4: the middle estimate sits 3.8-fold (0.58 log units) below what was measured, outside the stated range (above it).
By their numbers in this assay, from the lowest: compounds 2 and 3 (each within the scatter of the next); then compounds 4 and 1 (each within the scatter of the next).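

At this saturated ring carbon, the choice of side group matters in this assay: benzylamino in place of methyl(phenylsulfonyl)amino gives a weaker binder (a 3.1-fold higher number from compound 3 to compound 4 (0.49 log units; beyond the scatter)). A benzylic amine therefore does not keep its low number in every placement, since the shorter benzylamino also trails ((1-phenylethyl)amino)methyl (a 3.3-fold higher number from compound 2 to compound 4 (0.52 log units; beyond the scatter)), while it cannot be told apart from ((phenylsulfonyl)amino)methyl (a 1.3-fold lower number from compound 1 to compound 4 (0.13 log units; within the scatter)). No measurement in hand explains these steps.

Open, on these data alone, is how methyl(benzyl)amino or plain (phenylsulfonyl)amino would read at this ring carbon, which would separate the methyl on the nitrogen from the exchange of phenylsulfonyl for benzyl. Also open, as far as these compounds go, is whether the ((1-phenylethyl)amino)methyl result depends on its methylene link or on the methyl at its benzylic carbon, which 1-phenylethylamino or (benzylamino)methyl would address.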